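Ring nitrogen substituent change: compound 3 to compound 4

The source may report more compounds than this note shows. Statements on the series, on what has been measured and on what is new or still open speak of the compounds shown alone.

Measured so far:
compound 1 `CC[C@@H]1C(=O)N(C)c2cnc(-n3ccnc3-c3ccc(F)cc3)nc2N1CCC(F)(F)F` gives 42 nM
compound 2 `CCC1C(=O)N(C)c2cnc(-n3ccnc3-c3ccc(F)cc3)nc2N1c1ccc(F)cc1` gives 15 nM
compound 3 `CCC1C(=O)N(C)c2cnc(-n3ccnc3-c3ccc(F)cc3)nc2N1C1CCC(F)(F)C1` gives 13 nM

Among the compounds with values here, in an assay on isolated protein for inhibition of serine/threonine-protein kinase PLK2 (Homo sapiens), read by TR-FRET, with a stated time of 60 min (on this read-out lower numbers stand for stronger inhibition and higher numbers for weaker inhibition), compound 3 sits within the scatter of compound 2; the step of a 1.2-fold lower number from compound 2 to compound 3 (0.06 log units; within the scatter) is the only measured one-place change, and it is small. Within the data shown here, compound 1, with a trifluoroethyl group on the ring nitrogen, gives 42 nM and stands apart from compound 3 beyond the scatter, though no single-place step links the two.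

Compound 4 `CCC1C(=O)N(C)c2cnc(-n3ccnc3-c3ccc(F)cc3)nc2N1c1ccc(C#N)cc1` differs from compound 3 by 4-cyanophenyl in place of 3,3-difluorocyclopentyl on a nitrogen on an aromatic ring in a ring. The nearest measured step, from an aryl group to the cycloalkyl group, was within the scatter, so a return to an aryl group is expected to move the number little. The expected step is a 1.4-fold higher number from compound 3 to compound 4 (0.14 log units; within the scatter), none beyond the scatter. Compound 4 is therefore estimated at 18 nM, between 6 nM and 55 nM.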

Compound 4, half-maximal inhibitory concentration: 31 nM
For compound 4 the middle estimate is 1.7-fold (0.24 log units) below the measured one; the range from low to high includes it.
By their numbers in this assay, from the lowest: compounds 3 and 2 (each within the scatter of the next); then compounds 4 and 1 (each within the scatter of the next).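

In this assay the substituent on this nitrogen is not indifferent to every exchange: 4-cyanophenyl in place of 3,3-difluorocyclopentyl gives a 2.4-fold higher number from compound 3 to compound 4 (0.38 log units; beyond the scatter) and lies beyond the scatter, unlike the earlier exchange of 4-fluorophenyl for that cycloalkyl group. The aryl group's own substituent also registers, with cyano in place of fluoro on an aromatic carbon giving a 2.1-fold higher number from compound 2 to compound 4 (0.32 log units; beyond the scatter) and both steps remaining modest. No supporting data are available to explain these steps.

From the compounds shown here alone, how an amine or a carboxylic acid on the phenyl ring would read remains open, as does the effect of a plain cyclopentyl group at this nitrogen.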